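The source may hold more compounds than are shown below. What is called first, only, known or untested is meant among the compounds shown, and "the series" means these compounds.

Measured in a functional assay on DU-145 cells (Homo sapiens) for antiproliferative activity, read by MTT assay, with a stated time of 72 h; on this read-out lower numbers stand for stronger inhibition and higher numbers for weaker inhibition:
Compound 1 `COc1cccc(N(C)S(=O)(=O)C2CC3OC2C(c2ccc(NC(=O)CCCCCCC(=O)O)cc2)=C3c2ccc(O)cc2)c1`: 62200 nM
Compound 2 `CCN(c1ccc(C)cc1)S(=O)(=O)C1CC2OC1C(c1ccc(NC(=O)CCCCCCC(=O)O)cc1)=C2c1ccc(O)cc1`: 53500 nM

Among the compounds with values here, compound 2, at 53500 nM, cannot be told apart from the only other measured compound, the step being a 1.2-fold lower number from compound 1 to compound 2 (0.07 log units; within the scatter). Compound 3 `CCN(c1ccc(OC)cc1)S(=O)(=O)C1CC2OC1C(c1ccc(NC(=O)CCCCCCC(=O)O)cc1)=C2c1ccc(O)cc1` carries methoxy in place of methyl on an aromatic carbon, para to a large group (methoxy in place of methyl on an aromatic carbon). Within the data shown here, only that one step bears on this change, since it also alters the aryl group on the sulfonyl sulfur, so no shift beyond the scatter is expected in this assay. The expected step is a 1.0-fold higher number from compound 2 to compound 3 (0.01 log units; within the scatter). For compound 3 the estimated value is 55000 nM, with an expected range of 30000 nM to 100000 nM.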

Compound 3, half-maximal inhibitory concentration: 24400 nM
For compound 3 the middle estimate is 2.3-fold (0.35 log units) above the measured one; measured number below the stated range.
By their numbers in this assay, from the lowest: compound 3; then compounds 2 and 1 (each within the scatter of the next).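

In this assay the group para to a large group on this aromatic ring proves able to shift the number, with methoxy in place of methyl giving a modest change beyond the scatter (a 2.2-fold lower number from compound 2 to compound 3 (0.34 log units; beyond the scatter)). The full exchange on the sulfonyl sulfur, ethyl(4-methoxyphenyl)amino in place of (3-methoxyphenyl)(methyl)amino, is likewise modest (a 2.5-fold lower number from compound 1 to compound 3 (0.41 log units; beyond the scatter)). No measurement shown accounts for this shift.
On these data alone, whether the shift is specific to methoxy remains open. Ethoxy, hydroxy, fluorine or a dimethylamino group at the same place could settle how far it extends.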